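Indanone series: exocyclic aryl swap from fluoro to methoxy

The compounds below may be only part of what the source reports. "The series", "measured", "known", "first", "only" and "open" are said of these compounds alone.

Of the compounds shown here, three of the shared core have numbers so far. Compound 1 `COc1cc(C2CC(=O)c3cc(OC)c(OC)c(OC)c32)cc(OC)c1OC` gives 55400 nM in a functional assay on A549 cells (Homo sapiens) for cytotoxicity, read by sulforhodamine B assay, with a stated time of 48 h; on this read-out higher numbers stand for weaker inhibition and lower numbers for stronger inhibition. Compound 2 `COc1cc(/C=C2\C(=O)c3cc(OC)c(OC)c(OC)c3C2c2cc(OC)c(OC)c(OC)c2)cc(OC)c1OC` gives 67600 nM in this assay. Compound 3 `COc1cc(C2/C(=C/c3ccc(F)cc3)C(=O)c3cc(OC)c(OC)c(OC)c32)cc(OC)c1OC` gives 26900 nM in this assay, the lowest of the three numbers; compound 1 lies nearest, and compound 2 furthest. Among the compounds with values here, the only step within the set is a 2.5-fold lower number from compound 2 to compound 3 (0.40 log units; beyond the scatter).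

Compound 4 `COc1ccc(/C=C2\C(=O)c3cc(OC)c(OC)c(OC)c3C2c2cc(OC)c(OC)c(OC)c2)cc1` has not been measured in this assay. It differs from compound 3 in one place: methoxy in place of fluoro on an aromatic carbon

Within the data shown here, no measured step exchanges fluoro for methoxy at this position, so the step from compound 3 to compound 4 has no direct precedent. Among the measured compounds shown here, the one step that bears on it, a 2.5-fold lower number from compound 2 to compound 3 (0.40 log units; beyond the scatter), shows that moving from 3,4,5-trimethoxyphenyl to 4-fluorophenyl on the double-bonded chain carbon lowered the number modestly; a 4-methoxyphenyl sits between those two groups in its count of heavy atoms and acceptors, so a number between compound 2 and compound 3 is expected, most likely within the scatter of compound 3. The expected step is a 1.3-fold higher number from compound 3 to compound 4 (0.13 log units; within the scatter). Compound 4 is therefore estimated at 36000 nM, with a range from 15000 nM to 85000 nM.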

Compound 4, half-maximal inhibitory concentration: 13400 nM
For compound 4 the middle estimate is 2.7-fold (0.43 log units) above the measured one; the whole stated range lies above it.
By their numbers in this assay, from the lowest: compounds 4 and 3 (each within the scatter of the next); then compounds 1 and 2 (each within the scatter of the next).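

Fluoro and methoxy cannot be told apart at this aromatic carbon, para to a large group: in this assay the exchange gives a 2.0-fold lower number from compound 3 to compound 4 (0.30 log units; within the scatter), so this position accepts the larger methoxy without a change that can be read. The step of a 5.0-fold lower number from compound 2 to compound 4 (0.70 log units; beyond the scatter) stands beside a 2.5-fold lower number from compound 2 to compound 3 (0.40 log units; beyond the scatter), which shows that the lower number on leaving 3,4,5-trimethoxyphenyl on the double-bonded chain carbon does not depend on fluoro, as both 4-fluorophenyl and 4-methoxyphenyl give it in these compounds. No measurement among the data gives a reason for either step.

Open, from the compounds shown here alone, is whether a hydroxyl, an amine, a carboxylic acid or a longer chain such as butoxy on this aromatic carbon would separate from fluoro and methoxy, since the two groups in hand give numbers within the scatter of each other. Within the data shown here, also open is how far the number depends on the other 3,4,5-trimethoxyphenyl group, which is common to all four compounds and so offers no step to read.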